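The compounds below may be only part of what the source reports. "The series", "measured", "known", "first", "only" and "open" are said of these compounds alone.

Measured in a functional assay on SW-620 cells (Homo sapiens) for cytotoxicity, read by MTT assay, with stated times of 4 h and 72 h, tested at 10 uM; on this read-out higher numbers stand for weaker inhibition and lower numbers for stronger inhibition:

compound 1 `Cc1cc(Nc2ccc(C(=O)/C=C/c3ccc4ccccc4c3)cc2)n2nc(SCc3ccc(C(F)(F)F)cc3)nc2n1` gives 1450 nM
compound 2 `C=CCSc1nc2nc(C)cc(Nc3ccc(C(=O)/C=C/c4ccc5ccccc5c4)cc3)n2n1` gives 920 nM
compound 3 `O=C(/C=C/c1ccc2ccccc2c1)c1ccc(Nc2cc(-c3ccccc3)nc3ncnn23)cc1` gives 790 nM

Compound 1 lies within the scatter of both other compounds, so these three numbers set no order among themselves.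

Compound 4 `CCCSc1nc2nc(C)cc(Nc3ccc(C(=O)/C=C/c4ccc5ccccc5c4)cc3)n2n1` departs from compound 1 in one place: ethyl in place of 4-(trifluoromethyl)phenyl on a saturated chain carbon bound to a sulfur. For the measured compounds named here, one measured step bears on this change, with vinyl in place of 4-(trifluoromethyl)phenyl at that same place: a 1.6-fold lower number from compound 1 to compound 2 (0.20 log units; within the scatter) (a single pair, so thin evidence). Going by the values given here, compound 3 offers no step at this place.

Vinyl is the closest measured group to ethyl, so a step of similar small size is expected in this assay, leaning toward a lower number but not beyond the scatter. The expected step is a 1.5-fold lower number from compound 1 to compound 4 (0.16 log units; within the scatter) (an estimate resting on that single pair). The estimate for compound 4 is 1000 nM (expected range 500 nM to 2000 nM).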

Compound 4, half-maximal inhibitory concentration: 1070 nM
Compound 4: the middle estimate sits 1.1-fold (0.03 log units) below what was measured; the measured number falls inside the stated range.
By their numbers in this assay, from the lowest: compounds 3, 2, 4 and 1 (each within the scatter of the next).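

In this assay the exchange of 4-(trifluoromethyl)phenyl for ethyl on a saturated chain carbon bound to a sulfur (a 1.4-fold lower number from compound 1 to compound 4 (0.13 log units; within the scatter)) takes away the aromatic ring and cuts the group from 10 heavy atoms to 2, yet the two compounds stay within the scatter, which gives this place a second pair alongside the earlier vinyl one. Ethyl and vinyl also cannot be told apart at this place (a 1.2-fold higher number from compound 2 to compound 4 (0.07 log units; within the scatter)), so among compounds 1, 2 and 4 neither the aromatic ring nor the double bond separates the numbers. No evidence on the reason for this is at hand.

As far as these compounds go, whether an amine, a carboxylic acid or a longer chain at this place would give a step beyond the scatter stays open. Compound 3 differs from the others in more than one place, so it says nothing about this position.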